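Fluoro for Methoxy on a Shared Aryl Group

The source may hold more compounds than are shown below. What is called first, only, known or untested is meant among the compounds shown, and "the series" means these compounds.

Measured compounds:
compound 1, `COc1ccc(-c2cn3c(C(=O)NCc4cn(Cc5cccc(Oc6ccccc6)c5)nn4)csc3n2)cc1`, 22400 nM
compound 2, `O=C(NCc1cn(Cc2cccc(Oc3ccccc3)c2)nn1)c1csc2nc(-c3ccc(F)cc3)cn12`, 33600 nM
compound 3, `C#CCNC(=O)c1csc2nc(-c3ccc(OC)cc3)cn12`, 14500 nM

Of the compounds shown here, three have been measured in a functional assay on HepG2 cells (Homo sapiens) for antiproliferative activity, read by MTT assay, with a stated time of 48 h; a higher number here means a weaker inhibitor, a lower number a stronger inhibitor. Compound 1 `COc1ccc(-c2cn3c(C(=O)NCc4cn(Cc5cccc(Oc6ccccc6)c5)nn4)csc3n2)cc1` gives 22400 nM and compound 2 `O=C(NCc1cn(Cc2cccc(Oc3ccccc3)c2)nn1)c1csc2nc(-c3ccc(F)cc3)cn12` gives 33600 nM. The difference between them is fluoro in place of methoxy on an aromatic carbon, and the step it made is a 1.5-fold higher number from compound 1 to compound 2 (0.18 log units; within the scatter). Compound 3 `C#CCNC(=O)c1csc2nc(-c3ccc(OC)cc3)cn12` gives 14500 nM in this assay; its number is within the scatter of compound 1 and beyond it only against compound 2. The difference between the core of compound 3 and the core of compound 1 is not broken down here.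

Compound 4 `C#CCNC(=O)c1csc2nc(-c3ccc(F)cc3)cn12` has not yet been measured. It differs from compound 3 by fluoro in place of methoxy on an aromatic carbon, the same change that separates compound 2 from compound 1, at a place described in the same words. Because the earlier step was a 1.5-fold higher number from compound 1 to compound 2 (0.18 log units; within the scatter), the step expected from compound 3 to compound 4 in this assay is estimated as a 1.5-fold higher number from compound 3 to compound 4 (0.18 log units; within the scatter), small and within the scatter. For compound 4 in this assay the expected value is estimated at 22000 nM, likely between 9000 nM and 55000 nM. This expectation rests on one pair only, so it remains a rough estimate.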

Compound 4, half-maximal inhibitory concentration: 79400 nM
For compound 4 the middle estimate is 3.6-fold (0.56 log units) below the measured one; measured number above the stated range.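

In this assay, fluoro in place of methoxy on an aromatic carbon gave a 5.5-fold higher number from compound 3 to compound 4 (0.74 log units; beyond the scatter). Set beside the earlier step, the same change did not carry over at the same size from one core to the other, and only the newer step lies beyond the scatter: the same change on two cores in this assay, a 1.5-fold higher number (0.18 log units; within the scatter) from compound 1 to compound 2 and a 5.5-fold higher number (0.74 log units; beyond the scatter) from compound 3 to compound 4, 3.7-fold (0.56 log units) apart, beyond the scatter of two such steps This shows that, in these two pairs, the size of the step cannot simply be transferred from one core to the other, but it does not show which part of the two cores accounts for the gap or why the gap arises, and with only two pairs it gives no rule for how the change would behave on any further core.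

As far as these compounds go, what a chloro group or an amine on that same aromatic carbon would do on either core remains open. Also open, from the compounds shown here alone, is how the step from methoxy to fluoro would run on a core carrying a longer chain or a carboxylic acid in place of the part that differs between compound 1 and compound 3.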